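Benzyl ether swap across two related cores

The compounds below may be only part of what the source reports. "The series", "measured", "known", "first", "only" and "open" are said of these compounds alone.

Two cores are compared here. Compound 1 `Cc1ccc(NC(=S)NC(=O)c2ccc(OCc3ccc(Cl)cc3Cl)cc2)cc1-c1nc2ccccc2[nH]1` gives 11600 nM in a functional assay on HT-29 cells (Homo sapiens) for inhibition, read by MTT assay, with a stated time of 48 h; on this read-out higher numbers stand for weaker inhibition and lower numbers for stronger inhibition. Its partner compound 2 `Cc1ccc(NC(=S)NC(=O)c2ccc(OCc3ccc(F)cc3)cc2)cc1-c1nc2ccccc2[nH]1` gives 1910 nM in this assay, and the step from the one to the other is a 6.1-fold lower number from compound 1 to compound 2 (0.78 log units; beyond the scatter). The change that produces it is 4-fluorophenyl in place of 2,4-dichlorophenyl on a saturated chain carbon bound to an oxygen on an aromatic ring.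

Compound 3 `Cc1ccc(NC(=O)NC(=O)c2ccc(OCc3ccc(Cl)cc3Cl)cc2)cc1-c1nc2ccccc2[nH]1` carries the second core and gives 2620 nM in this assay. It stands second highest of the three measured numbers; against compound 2 it lies within the scatter, and against compound 1 it lies beyond it. The difference between the core of compound 1 and the core of compound 3 is not broken down here.

Compound 4 `Cc1ccc(NC(=O)NC(=O)c2ccc(OCc3ccc(F)cc3)cc2)cc1-c1nc2ccccc2[nH]1` is not yet measured. Going by the values given here, it arises from compound 3 by 4-fluorophenyl in place of 2,4-dichlorophenyl on a saturated chain carbon bound to an oxygen on an aromatic ring, the same change as the one from compound 1 to compound 2, made at the same place. Among the compounds with values here, on the second core the step from compound 3 to compound 4 is expected to be a 5.2-fold lower number from compound 3 to compound 4 (0.72 log units; beyond the scatter), a little smaller than the measured one, because only one precedent, a 6.1-fold lower number from compound 1 to compound 2 (0.78 log units; beyond the scatter), is available and it comes from a different core. Compound 4 is therefore expected to give about 500 nM in this assay, estimated between 150 nM and 1600 nM.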

Compound 4, half-maximal inhibitory concentration: 980 nM
For compound 4 the middle estimate is 2.0-fold (0.29 log units) below the measured one; the range from low to high includes it.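

On the core of compound 3, 4-fluorophenyl in place of 2,4-dichlorophenyl in this assay gives a 2.7-fold lower number from compound 3 to compound 4 (0.43 log units; beyond the scatter), the same direction as on the core of compound 1. This rests on one pair per core, so it supports carrying the change between these two cores only and says nothing about any further core or any other cell line. The two steps cannot be told apart in size, so the data give no ground for saying that either core responds more strongly to the change: the same change on two cores in this assay, a 6.1-fold lower number (0.78 log units; beyond the scatter) from compound 1 to compound 2 and a 2.7-fold lower number (0.43 log units; beyond the scatter) from compound 3 to compound 4, 2.3-fold (0.36 log units) apart, within the scatter of two such steps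

The compounds shown leave open which part of the change matters, since both chlorines leave and the fluorine enters in a single move; a plain benzyl group, or a benzyl group carrying one chlorine, would separate these contributions. Also open, on these data alone, is whether the same step appears with a quite different group on the benzyl ring, such as a methoxy group, an amine or a carboxylic acid.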